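This account rests on a few compounds, and the source may have more. Where it says the series, first, only, none or still open, it means among the compounds named here.

Working notes on the series: the compounds share one core and differ in a single group on an aromatic carbon. In a functional assay on the whole organism for inhibition, with Rattus norvegicus as the target (a lower number here means a stronger inhibitor, a higher number a weaker inhibitor), compound 1 (`O=C1ON=C(c2cccs2)/C1=C/c1ccc(O)cc1`) gives 4200 nM, compound 2 (`O=C1ON=C(c2cccs2)/C1=C/c1ccc(F)cc1`) gives 4800 nM and compound 3 (`O=C1ON=C(c2cccs2)/C1=C/c1ccc(Cl)cc1`) gives 6200 nM. Compound 3 therefore stands within the scatter of both others, with a 1.3-fold higher number from compound 2 to compound 3 (0.11 log units; within the scatter) and a 1.5-fold higher number from compound 1 to compound 3 (0.17 log units; within the scatter). The remaining step, a 1.1-fold higher number from compound 1 to compound 2 (0.06 log units; within the scatter), is also within the scatter.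

Compound 4 (`O=C(O)COc1ccc(/C=C2\C(=O)ON=C2c2cccs2)cc1`) has carboxymethoxy in place of chloro on an aromatic carbon, para to a large group: carboxymethoxy in place of chloro on an aromatic carbon. The three measured steps concern this same place, but they only exchange hydroxy, fluoro and chloro. For the measured compounds named here, no measured compound carries carboxymethoxy, so they offer only weak guidance for a change of this size. A modest step toward a lower number is expected in this assay, though a step in the other direction cannot be excluded. The expected change is a 2.1-fold lower number from compound 3 to compound 4 (0.32 log units; beyond the scatter). For compound 4 the estimated value is 3000 nM, with an expected range of 500 nM to 15000 nM.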

Compound 4, half-maximal inhibitory concentration: 100000 nM
Beside the measured number, compound 4's estimate is 33-fold (1.52 log units) below it, outside the stated range (above it).
By their numbers in this assay, from the lowest: compounds 1, 2 and 3 (each within the scatter of the next); then compound 4.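

In this assay, this position on the aromatic carbon does not tolerate every group: hydroxy, fluoro and chloro stay within the scatter of one another, whereas carboxymethoxy brings a 16-fold higher number from compound 3 to compound 4 (1.21 log units; beyond the scatter) and a 21-fold higher number from compound 2 to compound 4 (1.32 log units; beyond the scatter) as large steps beyond the scatter. The same holds when the hydroxy oxygen of compound 1 is kept and only carboxymethyl is added to it, with a 24-fold higher number from compound 1 to compound 4 (1.38 log units; beyond the scatter) as the result, so keeping that oxygen does not preserve the level of compound 1. No measurement shown here bears on the cause of these steps.

The shown compounds do not separate the effect of the chain from that of its terminal carboxylic acid. A simple methoxy, the methyl ester of the same chain or the corresponding primary amide at this position would address that question.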